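The compounds below may be only part of what the source reports. "The series", "measured", "known", "first", "only" and "open" are said of these compounds alone.

Working notes on the series. Compound 1 `CC(C)(C)OC(=O)Nc1cccc(-c2csc(NC(=O)CCCCCC(=O)NO)n2)c1` carries a hydroxyamino terminus on the shared core; in an assay on isolated protein for inhibition of protein deacetylase HDAC6 (Homo sapiens), read by fluorescence, with a stated time of 17 h (on this read-out higher numbers stand for weaker inhibition and lower numbers for stronger inhibition), compound 1 sits at the limit < 0.17 nM, which is the limit of < 0.17 nM in this assay, at which 1 of the 3 values shown sits. Compound 2 `CC(=O)Nc1cccc(-c2csc(NC(=O)CCCCCC(=O)Nc3ccccc3N)n2)c1` and compound 3 `CCOC(=O)Nc1cccc(-c2csc(NC(=O)CCCCCC(=O)Nc3ccccc3N)n2)c1` carry instead the (2-aminophenyl)amino terminus. In this assay compound 2 gives 11200 nM. Compound 3 sits at the limit > 30000 nM, which is the limit of > 30000 nM in this assay, at which 1 of the 3 values shown sits. Within the data shown here, the single measured step, an at least 2.6-fold higher number from compound 2 to compound 3 (0.42 log units; beyond the scatter), concerns the carbamate end only. Of the three values shown, compound 3 is the one at the upper limit, with no number behind it in this assay.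

Compound 4 `CCOC(=O)Nc1cccc(-c2csc(NC(=O)CCCCCC(=O)NO)n2)c1` is the next member; relative to compound 3 the change is hydroxy in place of 2-aminophenyl on an amide-type nitrogen. Among the measured compounds shown here, no measured pair differs in exactly this way, so no measured step bears on it directly, and the carbamate step says nothing about the terminus. For the measured compounds named here, the one guide is compound 1, whose value in this assay is the limit < 0.17 nM. A very large fall in the number is therefore expected, an at least 150000-fold lower number from compound 3 to compound 4 (5.17 log units; beyond the scatter). For compound 4 the estimate in this assay is 0.2 nM, with a range from 0.04 nM to 1.5 nM, and a fair chance that only a limit is reported.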

Compound 4, half-maximal inhibitory concentration: 0.79 nM
The estimate for compound 4 lay 4.0-fold (0.60 log units) below the measured number; the measured number falls inside the stated range.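

Hydroxy in place of 2-aminophenyl on an amide-type nitrogen, with the ethyl carbamate end held fixed, gives in this assay an at least 37000-fold lower number from compound 3 to compound 4 (4.57 log units; beyond the scatter), the first measured step at this position and a large one. The carbamate end still registers with the hydroxyamino terminus in place: ethyl in place of tert-butyl on an oxygen next to a carbonyl group gives an at least 4.6-fold higher number from compound 1 to compound 4 (0.66 log units; beyond the scatter), so the terminus alone does not set the value among these compounds. The step at the terminus is a bound and not an exact size, and the value of compound 3 is a limit and not a number: the limit of > 30000 nM in this assay, at which 1 of the 4 values shown sits.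

The carbamate step is likewise a bound, and the value of compound 1 is also a limit and not a number: the limit of < 0.17 nM in this assay, at which 1 of the 4 values shown sits. Open are how a carboxylic acid or a primary amide would read in place of the hydroxyamino terminus, how a longer chain would read on the shared core, and how the acetyl end of compound 2 would read with a hydroxyamino terminus.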